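Swapping the amide group of a weak compound

This account rests on a few compounds, and the source may have more. Where it says the series, first, only, none or still open, it means among the compounds named here.

In a functional assay on MCF7 cells (Homo sapiens) for antiproliferative activity, read by MTT assay, with a stated time of 48 h (on this read-out higher numbers stand for weaker inhibition and lower numbers for stronger inhibition), compound 3 `CCn1c(C(=O)Nc2cccc(C(F)(F)F)c2)ccc1C(CC)(CC)c1ccc(OCCC(O)(CC)CC)c(C)c1` gives > 50000 nM, which is a limit and not a number. By contrast, compound 1 `CCn1c(C(=O)NCCN(C)C)ccc1C(CC)(CC)c1ccc(OCCC(O)(CC)CC)c(C)c1` gives 430 nM and compound 2 `CCn1c(C(=O)NCCN)ccc1C(CC)(CC)c1ccc(OCCC(O)(CC)CC)c(C)c1` gives 670 nM.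

Compound 4 `CCOC(=O)C(CC(=O)OC)NC(=O)c1ccc(C(CC)(CC)c2ccc(OCCC(O)(CC)CC)c(C)c2)n1CC` differs from compound 3 in one place, on an amide-type nitrogen: a group of 11 heavy atoms (7 carbon, 4 oxygen; no ring) in place of a group of 10 heavy atoms (7 carbon, 3 fluorine; one six-membered aromatic ring of carbon only), on an amide-type nitrogen. The 3-(trifluoromethyl)phenyl leaves, and a group with no ring enters.

Two measured steps change this same nitrogen, and both are large: an at least 110-fold higher number from compound 1 to compound 3 (2.06 log units; beyond the scatter) and an at least 74-fold higher number from compound 2 to compound 3 (1.87 log units; beyond the scatter). The step between the two chains is small, a 1.6-fold higher number from compound 1 to compound 2 (0.19 log units; within the scatter). Compound 4 carries neither the 2-(dimethylamino)ethyl of compound 1 nor the 2-aminoethyl of compound 2, so it is expected to stay much nearer to compound 3, given an at least 74-fold higher number from compound 2 to compound 3 (1.87 log units; beyond the scatter). For the measured compounds named here, no measured step covers the entering group, so only a modest move towards a lower number is expected in this assay, and another limit is quite possible. The expected change is an at least 3.3-fold lower number from compound 3 to compound 4 (0.52 log units; beyond the scatter). The estimated value for compound 4 is 15000 nM, with an expected range from 3000 nM to 60000 nM.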

Compound 4, half-maximal inhibitory concentration: 390 nM
Compound 4: the middle estimate sits 38-fold (1.59 log units) above what was measured, outside the stated range (below it).
By their numbers in this assay, from the lowest: compounds 4, 1 and 2 (each within the scatter of the next). At a limit, above all of these: compound 3.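

Putting a group of carbon and oxygen only on this amide-type nitrogen, in place of the 3-(trifluoromethyl)phenyl, gives an at least 120-fold lower number from compound 3 to compound 4 (2.10 log units; beyond the scatter) in this assay. The entering group holds no amine, unlike the chains of compound 1 and compound 2, yet a 1.1-fold lower number from compound 1 to compound 4 (0.04 log units; within the scatter) and a 1.7-fold lower number from compound 2 to compound 4 (0.24 log units; within the scatter) both lie within the scatter, so a nitrogen in this chain is not required for activity at this level. Compound 3 stands at a limit and not at a number, so its step gives only a minimum size: the limit of > 50000 nM in this assay, at which 1 of the 4 values shown sits.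

What a plain phenyl on this nitrogen would give remains open, so the compounds shown cannot separate the ring from its trifluoromethyl. Also open, going by these compounds, is what a carboxylic acid or a short unbranched alkyl chain would give here.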